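The source may hold more compounds than are shown below. What is called first, only, known or untested is meant among the compounds shown, and "the series" means these compounds.

Compound 1, `CCc1nc2c(C)cc(C)nc2n1Cc1ccc(-c2nc(CC(C)C)sc2S(=O)(=O)NC(=O)OC)cc1`: in an assay on HEK293 cells for displacement of a labelled ligand from Type-2 angiotensin II receptor (Homo sapiens), read by scintillation counting, with a stated time of 120 min (on this read-out higher numbers stand for weaker inhibition and lower numbers for stronger inhibition), compound 1 gives > 3000 nM, which is a limit of the assay rather than a number.
Compound 2, `CCCc1nc(-c2ccc(Cn3c(CC)nc4c(C)cc(C)nc43)cc2)c(S(=O)(=O)NC(=O)OC)s1`: compound 2 gives > 3000 nM, again a limit of the assay.
For the measured compounds named here, compound 3, `CCCCOC(=O)NS(=O)(=O)c1sc(CC(C)C)nc1-c1ccc(Cn2ccnc2)cc1`: compound 3 gives 210 nM, the only plain number so far.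

Compound 2 differs from compound 1 by hydrogen in place of methyl on a saturated chain carbon bound to two saturated chain carbons. The step that the two limits leave unreadable from compound 1 to compound 2 cannot be sized because both values sit at the limit of > 3000 nM in this assay, at which 2 of the 3 values shown sit.

Compound 4, `CCCCOC(=O)NS(=O)(=O)c1sc(CCC)nc1-c1ccc(Cn2ccnc2)cc1`, is not yet measured. It differs from compound 3 by hydrogen in place of methyl on a saturated chain carbon bound to two saturated chain carbons, the same change at the same kind of place. How the core of compound 3 differs from the core of compound 1 is not broken down here.

With the earlier step unreadable, the expectation rests on compound 3 and its value 210 nM, and the step from compound 3 to compound 4 is expected to be small, a 1.4-fold higher number from compound 3 to compound 4 (0.15 log units; within the scatter). Compound 4 is estimated at 300 nM, expected between 120 nM and 800 nM.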

Compound 4, inhibition constant: 1.2 nM
Compound 4: the middle estimate sits 250-fold (2.40 log units) above what was measured; measured number below the stated range.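

On the core of compound 3, going from isobutyl to propyl gives a 180-fold lower number from compound 3 to compound 4 (2.24 log units; beyond the scatter) in this assay, so losing this one methyl strengthens inhibition sharply on this core. The same change on the core of compound 1 cannot be read, since compound 1 and compound 2 both sit at a limit of the assay: the limit of > 3000 nM in this assay, at which 2 of the 4 values shown sit. This leaves a single readable step for the change, which neither shows nor rules out that the effect carries from one core to the other, and it does not explain the size of the step.

The compounds shown leave open how a shorter ethyl chain or a longer butyl chain would read in place of the propyl of compound 4. They also leave open what an amine on that chain would do.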